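Thiazolidine acrylamide series: branched alkyl at the ring carbon

This account rests on a few compounds, and the source may have more. Where it says the series, first, only, none or still open, it means among the compounds named here.

Measured so far:
compound 1 `C#CC(=O)N1C(CC(C)CC(C)(C)C)SC[C@@H]1C(=O)OCC` gives 1100 nM in a functional assay on MV cells (Homo sapiens) for inhibition, read by sulforhodamine B assay; a lower number here means a stronger inhibitor, a higher number a weaker inhibitor
compound 2 `C#CC(=O)N1C(C(C)CCC)SC[C@@H]1C(=O)OCC` gives 500 nM in this assay

Two compounds are in hand, and they differ in the saturated substituent on the ring carbon that sits between the ring nitrogen and the ring sulfur. Compound 2 carries the shorter, singly branched chain and stands with the lowest of the two numbers; compound 1, with the longer and more heavily branched chain, gives the higher number, and the gap between them is beyond the scatter. Among the measured compounds shown here, no further pairs are available, so no trend beyond these two can be claimed.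

Compound 3 `C#CC(=O)N1C(C(C)(C)C)SC[C@@H]1C(=O)OCC` is not yet measured. The change from compound 2 is tert-butyl in place of 1-methylbutyl on a saturated ring carbon. Of the two measured compounds, the one with the larger branched group, compound 1, gave the weaker value, so a compact tert-butyl is not expected to fall far outside the range spanned by compound 1 and compound 2. The step of a 1.6-fold higher number from compound 2 to compound 3 (0.20 log units; within the scatter) is expected to be modest, if anything toward a slightly higher number, and may stay within the scatter. The value expected for compound 3 in this assay is 800 nM, with a range from 300 nM to 2500 nM.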

Compound 3, half-maximal inhibitory concentration: 900 nM
Estimate against measurement, compound 3: 1.1-fold (0.05 log units) below; measured number inside the range.
By their numbers in this assay, from the lowest: compounds 2, 3 and 1 (each within the scatter of the next, the first and the last beyond it).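

In this assay, tert-butyl in place of 1-methylbutyl on this saturated ring carbon gives a 1.8-fold higher number from compound 2 to compound 3 (0.26 log units; within the scatter), so the two groups cannot be told apart at this position, and a change in the branching of the substituent, with one heavy atom fewer, is accommodated here without a separable change in the number. Compound 3 at 900 nM also stands within the scatter of compound 1 at 1100 nM, while compound 1 and compound 2 remain beyond the scatter of each other, so compound 3 bridges the two and the single gap seen earlier no longer reads as a clean split between substituents. Nothing at hand accounts for these values.

As far as these compounds go, all three substituents are saturated branched alkyl groups, so it remains open whether an unbranched chain such as n-butyl, a cyclohexyl ring or a phenyl ring at this ring carbon would stay within the same span of numbers. Also open, from the compounds shown here alone, is how a chain carrying an amine or a hydroxyl group would read here, and whether the ethoxycarbonyl group can give way to a carboxylic acid with this substituent in place.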